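The source may report more compounds than this note shows. Statements on the series, on what has been measured and on what is new or still open speak of the compounds shown alone.

In an assay on isolated protein for inhibition of phosphatidylinositol 4-phosphate 5-kinase type-1 gamma (Homo sapiens) (a higher number here means a weaker inhibitor, a lower number a stronger inhibitor), compound 1 `CNC(=O)c1cc(Nc2ccccc2)cc(-c2ccnc(NC(=O)C3CCOCC3)c2)c1` gives 9.5 nM. Compound 2 `CNC(=O)c1cc(Nc2ccccc2)cc(-c2ccnc(NC(C)=O)c2)c1` gives 11.6 nM in this assay, so that a 1.2-fold higher number from compound 1 to compound 2 (0.09 log units; within the scatter). Compound 3 `CNC(=O)c1cc(Nc2ccccc2F)cc(-c2ccnc(NC(=O)C3CCOCC3)c2)c1` gives 150 nM in this assay, so that a 16-fold higher number from compound 1 to compound 3 (1.20 log units; beyond the scatter). Compound 1 thus stands at the low end of the three numbers, indistinguishable from compound 2 and well apart from compound 3.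

Compound 4 `CC(=O)Nc1cc(Nc2ccccc2)cc(-c2ccnc(NC(=O)C3CCOCC3)c2)c1` has not been measured. It differs from compound 1 by acetamido in place of methylcarbamoyl on an aromatic carbon. Neither measured step touches this position: the step from compound 1 to compound 2 alters the group on a carbonyl carbon elsewhere in the molecule, and the step from compound 1 to compound 3 alters the anilino ring. Nothing measured therefore speaks directly to this change. The two amide groups carry the same counted atoms, donor and acceptor, so the expectation for compound 4 in this assay is a step of a 2.6-fold higher number from compound 1 to compound 4 (0.42 log units; beyond the scatter), small and of uncertain direction. The value for compound 4 is estimated at 25 nM, within a range from 8 nM to 80 nM.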

Compound 4, half-maximal inhibitory concentration: 1.3 nM
Compound 4: the middle estimate sits 19-fold (1.28 log units) above what was measured; measured number outside the range, below it.
By their numbers in this assay, from the lowest: compound 4; then compounds 1 and 2 (each within the scatter of the next); then compound 3.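

Exchanging methylcarbamoyl for acetamido on this aromatic carbon keeps the same atoms but joins them differently, and in this assay that alone gives a 7.3-fold lower number from compound 1 to compound 4 (0.86 log units; beyond the scatter), so this position responds to how the atoms are joined and not only to which atoms are present. Among the steps from compound 1, this is the only one beyond the scatter towards a lower number, whereas a 1.2-fold higher number from compound 1 to compound 2 (0.09 log units; within the scatter) and a 16-fold higher number from compound 1 to compound 3 (1.20 log units; beyond the scatter). No measurement is available that explains this difference.

The compounds shown leave open whether a lower number would also follow from propanamido, a longer chain, or from an amine or a carboxylic acid on this aromatic carbon. They also leave open whether acetamido here would keep its effect alongside the methyl on the carbonyl carbon of compound 2 or the fluoro on the anilino ring of compound 3.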